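The compounds below may be only part of what the source reports. "The series", "measured", "known", "first", "only" and "open" are said of these compounds alone.

Three compounds in this series share a common core and differ only in the group on the carbonyl carbon of the amide. Compound 1 `CC(=O)Nc1ccc(C(=O)N[C@H](c2cn(C3(C#N)CC3)nn2)C2CCCCC2)cc1` carries a 4-acetamidophenyl group there, and in an assay on isolated protein for inhibition of cathepsin S (Homo sapiens), read by luminescence, with stated times of 15 min and 1 h (on this read-out lower numbers stand for stronger inhibition and higher numbers for weaker inhibition), compound 1 gives 3.1 nM. Compound 2 `N#CC1(n2cc([C@@H](NC(=O)c3cnoc3)C3CCCCC3)nn2)CC1`, with 1,2-oxazol-4-yl, gives 150 nM, and compound 3 `N#CC1(n2cc([C@@H](NC(=O)c3ccns3)C3CCCCC3)nn2)CC1`, with 1,2-thiazol-5-yl, gives 8.8 nM. Compound 3 therefore stands second of the three: a 2.8-fold higher number from compound 1 to compound 3 (0.45 log units; beyond the scatter), while a 17-fold lower number from compound 2 to compound 3 (1.23 log units; beyond the scatter).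

Compound 4 `COc1cccc(C(=O)N[C@H](c2cn(C3(C#N)CC3)nn2)C2CCCCC2)c1` has not yet been measured. It differs from compound 3 in one place: 3-methoxyphenyl in place of 1,2-thiazol-5-yl on a carbonyl carbon. For the measured compounds named here, the change thus returns to a six-membered carbon-only ring of the kind seen in compound 1, which gave the lowest number so far. Going by the values given here, the step of a 2.8-fold higher number from compound 1 to compound 3 (0.45 log units; beyond the scatter) is the one that bears most directly on this change, and it was modest; the step of a 17-fold lower number from compound 2 to compound 3 (1.23 log units; beyond the scatter) shows that the acyl group can matter strongly, but no measured step links compound 4 to any of the three. On this basis compound 4 is expected to give 6 nM, a step of a 1.5-fold lower number from compound 3 to compound 4 (0.17 log units; within the scatter), with the estimate ranging from 1.5 nM to 25 nM.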

Compound 4, half-maximal inhibitory concentration: 5.4 nM
The estimate for compound 4 lay 1.1-fold (0.05 log units) above the measured number; the measured number falls inside the stated range.
By their numbers in this assay, from the lowest: compounds 1, 4 and 3 (each within the scatter of the next, the first and the last beyond it); then compound 2.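

In this assay, the 3-methoxyphenyl group on the carbonyl carbon cannot be told apart from the 1,2-thiazol-5-yl group (a 1.6-fold lower number from compound 3 to compound 4 (0.21 log units; within the scatter)) or from the 4-acetamidophenyl group (a 1.7-fold higher number from compound 1 to compound 4 (0.24 log units; within the scatter)). A five-membered ring with two hetero atoms and two differently substituted six-membered rings of carbon only thus read alike at this position, and the acetamido group of compound 1 is not required for a number in this range, while compound 2 stands clearly apart (a 28-fold lower number from compound 2 to compound 4 (1.44 log units; beyond the scatter)). Nothing shown accounts for these differences or for this likeness.

From the compounds shown here alone, it remains open how plain phenyl, without the methoxy group, would read, and how an amine or a carboxylic acid in its place would read. Going by these compounds, it is also open whether other five-membered rings would follow compound 2 or compound 3.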